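The compounds below may be only part of what the source reports. "The series", "measured", "known", "first", "only" and "open" are said of these compounds alone.

In a functional assay on DU-145 cells (Homo sapiens) for inhibition, read by trypan blue exclusion, with a stated time of 96 h (a higher number here means a weaker inhibitor of growth, a lower number a stronger inhibitor of growth), compound 3 (`CN(C)c1ccc(/C=C(/SCc2ccc(Cl)cc2Cl)C(=O)c2ccc(Cl)cc2)cc1`) gives 50000 nM, level with compound 2 (`CN(C)c1ccc(/C=C(/SCc2ccc(Cl)c(Cl)c2)C(=O)c2ccc(Cl)cc2)cc1`) at 50000 nM. Among the measured compounds shown here, these two share the highest number so far. The gap between them and compound 1 (`Cc1ccc(CS/C(=C/c2cc([N+](=O)[O-])ccc2F)C(=O)c2ccc(Cl)cc2)cc1`) is larger than the scatter: compound 1 gives 1000 nM.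

Compound 4 (`Cc1ccc(CS/C(=C/c2ccc(N(C)C)cc2)C(=O)c2ccc(Cl)cc2)cc1`) keeps the rest of compound 3 and carries 4-methylphenyl in place of 2,4-dichlorophenyl on a saturated chain carbon bound to a sulfur.

For the measured compounds named here, one measured step touches this place. Swapping 3,4-dichlorophenyl for 2,4-dichlorophenyl gave no change at the digits printed from compound 2 to compound 3 (within the scatter), so that pair of compounds offers no sign of sensitivity here, although it tests only a dichlorophenyl swap. Going by the values given here, compound 1 bears the same 4-methylphenyl at 1000 nM, but it differs from compound 4 elsewhere, and no measured step isolates the group.

No shift beyond the scatter is therefore expected in this assay. The estimated change is a 1.3-fold lower number from compound 3 to compound 4 (0.10 log units; within the scatter). Compound 4 is expected at 40000 nM, with an estimated range of 15000 nM to 70000 nM.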

Compound 4, concentration for 50% growth inhibition: > 100000 nM
Compound 4 ended at the assay's limit; the forecaster's own chance of this, stated with the estimate: 30%; at least 2.5-fold (0.39 log units) between middle value and limit.
By their numbers in this assay, from the lowest: compound 1; then compounds 2 and 3 (each within the scatter of the next). At a limit, above all of these: compound 4.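

In this assay, compound 4 stands at a limit of the assay and not at a number, > 100000 nM, so the change to 4-methylphenyl can be read only as a floor: the limit of > 100000 nM in this assay, at which 1 of the 4 values shown sits.

The two floors, an at least 2.0-fold higher number from compound 3 to compound 4 (0.30 log units; that floor lies within the scatter) and an at least 2.0-fold higher number from compound 2 to compound 4 (0.30 log units; that floor lies within the scatter), do not show that this position responds beyond the scatter, though they do not show that it is flat either. With 4-methylphenyl held constant, the series now gives an at least 100-fold higher number from compound 1 to compound 4 (2.00 log units; beyond the scatter), which isolates a large effect of 4-(dimethylamino)phenyl in place of 2-fluoro-5-nitrophenyl on a double-bonded chain carbon bound to a double-bonded chain carbon.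

As far as these compounds go, the true size of the 4-methylphenyl step stays open. Also open, from the compounds shown here alone, is whether the nitro group or the fluorine carries the large step, and how an amine or a carboxylic acid on the benzyl ring would read.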